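The source may report more compounds than this note shows. Statements on the series, on what has been measured and on what is new or still open speak of the compounds shown alone.

Of the compounds shown here, two sharing one core have so far been tested in a functional assay, read by spectrophotometry, with a stated time of 30 min, tested at 30 uM; on this read-out lower numbers stand for a weaker effect and higher numbers for a stronger effect at the one concentration tested. Compound 1, `COc1cc(OC)cc(-n2c(-c3ccccc3)nc(C)c2C)c1`, gives 52.5% in this assay. Compound 2, `COc1ccc(-n2c(-c3ccc(F)cc3)nc(C)c2C)cc1`, gives 46.5% in this assay. Of the two numbers, that of compound 2 is the smaller, but its distance from compound 1 falls within the usual scatter of repeated measurements, so no real ordering of the two can be claimed.

Compound 3, `COc1ccc(-n2c(-c3ccccc3)nc(C)c2C)cc1`, awaits measurement in this assay. It differs from compound 2 in one place: hydrogen in place of fluoro on an aromatic carbon. Among the measured compounds shown here, no measured pair shows this same change, so nothing in the numbers at hand tells its effect. The step from compound 2 to compound 3 is expected to be small, in no direction beyond the scatter; the estimated step is a number 1.5 percentage points higher from compound 2 to compound 3 (within the scatter). Compound 3 is therefore expected to give 48% in this assay, with a likely range from 30% to 66%.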

Compound 3, a percentage reported as activity, at one concentration (the size of the read-out at that concentration, not a potency): 59.6%
For compound 3 the middle estimate is 11.6 percentage points below the measured one; measured number inside the range.
By their numbers in this assay, from the lowest: compounds 2, 1 and 3 (each within the scatter of the next, the first and the last beyond it).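

Replacing fluoro with hydrogen, the change from 4-fluorophenyl to phenyl, gives a number 13.1 percentage points higher from compound 2 to compound 3 (beyond the scatter) in this assay, the first step across a single place in this series. At this position on an aromatic carbon, para to a large group, fluoro and hydrogen are therefore not interchangeable on this read-out, and the compound with hydrogen gives the higher number. Nothing at hand accounts for the size or direction of this step.

This single pair cannot show whether the step belongs to fluoro in particular or would recur with other groups in the same place, such as a chlorine atom, an amine or a carboxylic acid. From the compounds shown here alone, whether the same change would give a similar step on another substitution pattern of the shared core also remains open.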